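Moving from 2-ethylphenyl to 3,4-dimethylphenyl: a small step expected

The compounds below may be only part of what the source reports. "The series", "measured", "known", "first", "only" and "open" are said of these compounds alone.

In a functional assay on HepG2 cells (Homo sapiens) for antiproliferative activity, read by MTT assay, with a stated time of 48 h (a higher number here means a weaker inhibitor, a lower number a stronger inhibitor), compound 1 (`COc1ccc(NC(=O)Nc2cccc(CNc3nccnc3Cl)c2)cc1`) gives 12000 nM and compound 2 (`CCc1ccccc1NC(=O)Nc1cccc(CNc2nccnc2Cl)c1`) gives 7860 nM. These two numbers lie within the usual scatter of repeated measurements, so compound 2 stands level with compound 1. Compound 3 (`Cc1ccc(NC(=O)Nc2cccc(CNc3nccnc3Cl)c2)cc1C`) has the same atoms as compound 2, joined differently, with 3,4-dimethylphenyl in place of 2-ethylphenyl on an amide-type nitrogen. Among the compounds with values here, only one measured change bears on this place: a 1.5-fold lower number from compound 1 to compound 2 (0.18 log units; within the scatter), where 2-ethylphenyl replaced 4-methoxyphenyl. One small step is a thin guide, but on that evidence no change beyond the scatter is expected in this assay. The estimated step is a 1.1-fold higher number from compound 2 to compound 3 (0.06 log units; within the scatter). For compound 3, the expected value is 9000 nM, with an estimated range of 4000 nM to 20000 nM.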

Compound 3, half-maximal inhibitory concentration: 10700 nM
For compound 3 the middle estimate is 1.2-fold (0.08 log units) below the measured one, and the stated range covers the measured number.
By their numbers in this assay, from the lowest: compounds 2, 3 and 1 (each within the scatter of the next).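

In this assay the same carbon atoms, arranged as 3,4-dimethylphenyl in place of 2-ethylphenyl on the amide-type nitrogen, give a 1.4-fold higher number from compound 2 to compound 3 (0.13 log units; within the scatter) and stay within the scatter. Set against the 4-methoxyphenyl group, the 3,4-dimethylphenyl group gives a 1.1-fold lower number from compound 1 to compound 3 (0.05 log units; within the scatter) and also stays within the scatter, so all three substituted phenyl groups at this position now read level with one another. No measurement at hand explains this reading.

From the compounds shown here alone, all three compounds carry a substituted phenyl ring at this position, so it remains open whether a ring bearing a carboxylic acid or an amine, or a longer chain in place of the ring, would move the number beyond the scatter. Going by these compounds, whether changes to the shared core would do so also remains open.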